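Replacing a hydroxyphenyl group with a nitrooxyphenyl group

The source may report more compounds than this note shows. Statements on the series, on what has been measured and on what is new or still open speak of the compounds shown alone.

Measured compounds:
- compound 1 `CN(C)CCn1cnnc1-c1cc(Oc2ccc(NC(=O)N/N=C/c3cccc(O)c3)cc2F)ccn1`: 780 nM
- compound 2 `CN(C)CCn1cnnc1-c1cc(Oc2ccc(NC(=O)N/N=C/c3cccc(Cl)c3Cl)cc2F)ccn1`: 72 nM
- compound 3 `CN(C)CCn1cnnc1-c1cc(Oc2ccc(NC(=O)N/N=C/c3c(O)ccc4ccccc34)cc2F)ccn1`: 890 nM

In a functional assay on NCI-H460 cells (Homo sapiens) for cytotoxicity, read by MTT assay, with a stated time of 72 h (a higher number here means a weaker inhibitor, a lower number a stronger inhibitor), compound 1 gives 780 nM and stands second highest of the three numbers. Its nearest neighbour is compound 3, whose value in this assay is 890 nM; the two differ by a 1.1-fold higher number from compound 1 to compound 3 (0.06 log units; within the scatter), which lies within the scatter. Compound 2 sits furthest away, with an 11-fold lower number from compound 1 to compound 2 (1.03 log units; beyond the scatter).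

Compound 4 `CN(C)CCn1cnnc1-c1cc(Oc2ccc(NC(=O)N/N=C/c3ccccc3O[N+](=O)[O-])cc2F)ccn1` has not yet been measured. It differs from compound 1 in one place: 2-(nitrooxy)phenyl in place of 3-hydroxyphenyl on a carbon with a double bond to nitrogen. For the measured compounds named here, the step most relevant here is the one from compound 1 to compound 2, where the hydroxyphenyl group left and a dichlorophenyl group entered, giving a large drop in the number. The step to compound 3, which kept a hydroxyl group, changed nothing beyond the scatter. Going by the values given here, since compound 4 likewise gives up the hydroxyl group, a drop is expected, though of uncertain size, because the group entering is not the one seen in compound 2 and its step of an 11-fold lower number from compound 1 to compound 2 (1.03 log units; beyond the scatter) may not transfer in full. Compound 4 is therefore expected to show a 3.1-fold lower number from compound 1 to compound 4 (0.49 log units; beyond the scatter) in this assay. The estimate for compound 4 is 250 nM, with a range from 80 nM to 800 nM.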

Compound 4, half-maximal inhibitory concentration: 1270 nM
The estimate for compound 4 lay 5.1-fold (0.71 log units) below the measured number; measured number outside the range, above it.
By their numbers in this assay, from the lowest: compound 2; then compounds 1, 3 and 4 (each within the scatter of the next).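

In this assay the 2-(nitrooxy)phenyl group gives only a 1.6-fold higher number from compound 1 to compound 4 (0.21 log units; within the scatter) and a 1.4-fold higher number from compound 3 to compound 4 (0.15 log units; within the scatter) at this carbon with a double bond to nitrogen, so giving up the hydroxyl group does not by itself bring the number down. Only the 2,3-dichlorophenyl group stands apart, with an 18-fold higher number from compound 2 to compound 4 (1.25 log units; beyond the scatter) as its gap to the new compound, so the earlier drop goes with that group and not with the loss of the hydroxyl group alone. No measurement at hand says why these groups differ here.

The compounds shown do not separate the two chlorine atoms, so it stays open whether one chlorine atom would be enough, or whether bromine atoms or methyl groups in their place would keep the low number. They also leave open how a phenyl ring carrying an amine or a carboxylic acid would read at this place.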